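Amide aryl variation and cytotoxicity in the chromone series

The source may hold more compounds than are shown below. What is called first, only, known or untested is meant among the compounds shown, and "the series" means these compounds.

Of the compounds shown here, three of the shared core have been measured in an ADME assay on HepG2 2.2.15 cells (Homo sapiens) for cytotoxicity, read by MTT assay, with stated times of 48 h and 9 days; a lower number here means that less compound is tolerated, a higher number that more compound is tolerated. Compound 1 `COc1ccc2c(=O)c(/C=C/C(=O)Nc3cccc(Cl)c3)coc2c1` gives 1100000 nM, compound 2 `COc1ccc2c(=O)c(/C=C/C(=O)Nc3ccccc3)coc2c1` gives 523000 nM, and compound 3 `COc1ccc2c(=O)c(/C=C/C(=O)Nc3cc(C)ccc3C)coc2c1` gives 1100000 nM. Compound 3 thus stands level with compound 1 at the digits shown, the two together being the highest of the three numbers; the only measured separation is a 2.1-fold higher number from compound 2 to compound 3 (0.32 log units; beyond the scatter), a modest step, while no change at the digits printed from compound 1 to compound 3 (within the scatter).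

Compound 4 `COc1cccc(NC(=O)/C=C/c2coc3cc(OC)ccc3c2=O)c1` differs from compound 3 by 3-methoxyphenyl in place of 2,5-dimethylphenyl on an amide-type nitrogen. Among the compounds with values here, no measured step exchanges a methoxy for methyl groups on this aryl ring. Within the data shown here, the steps that bear on it are those that vary the same ring: a 2.1-fold higher number from compound 2 to compound 3 (0.32 log units; beyond the scatter) shows that adding two methyl groups to a bare phenyl raises the tolerated concentration modestly, and no change at the digits printed from compound 1 to compound 3 (within the scatter) shows that a 3-chlorophenyl and a 2,5-dimethylphenyl are indistinguishable within the scatter. A single substituent in the 3-position of the phenyl, as in compound 1, gave the same number as compound 3, so compound 4 is expected to remain close to compound 3, with a 1.2-fold lower number from compound 3 to compound 4 (0.09 log units; within the scatter) expected to fall within the scatter or at most a modest lowering toward compound 2. Compound 4 is therefore estimated at 900000 nM in this assay, with a range from 400000 nM to 2000000 nM.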

Compound 4, half-maximal cytotoxic concentration: 1130000 nM
For compound 4 the middle estimate is 1.3-fold (0.10 log units) below the measured one, within the range that was stated.
By their numbers in this assay, from the lowest: compound 2; then compounds 1, 3 and 4 (each within the scatter of the next).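

In this assay, within the data shown here, 3-methoxyphenyl on the amide-type nitrogen cannot be told apart from either 2,5-dimethylphenyl (a 1.0-fold higher number from compound 3 to compound 4 (0.01 log units; within the scatter)) or 3-chlorophenyl (a 1.0-fold higher number from compound 1 to compound 4 (0.01 log units; within the scatter)), so this position now holds three differently substituted aryl groups that the assay does not separate, one of them the only group here with a hydrogen-bond acceptor. Methoxy in place of hydrogen on an aromatic carbon (a 2.2-fold higher number from compound 2 to compound 4 (0.33 log units; beyond the scatter)) gives a modest step, so the unsubstituted phenyl of compound 2 remains the only one of the four set apart, with each of the three substituted aryl compounds lying beyond the scatter from it. Nothing available explains why these three substituted aryl groups cannot be separated or why compound 2 stands apart.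

The compounds shown leave open whether a group of another kind on this aryl ring, such as an amine or a carboxylic acid, would separate from compounds 1, 3 and 4. They also leave open whether a longer chain on the amide-type nitrogen, in place of the aryl ring, would stay level with these compounds or fall toward compound 2.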